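A Swapped Five-Membered Ring Group on Compound 2

The compounds below may be only part of what the source reports. "The series", "measured", "known", "first", "only" and "open" are said of these compounds alone.

In a functional assay on NIH3T3 cells (Mus musculus) for inhibition, read by MTT assay, with a stated time of 72 h (a higher number here means a weaker inhibitor, a lower number a stronger inhibitor), compound 2 `C=C1CC[C@H]2[C@@](C)(CC[C@@H](O)[C@@]2(C)C(=O)OC)[C@@H]1CCC1=CCOC1=O` gives 60600 nM, within the scatter of both its measured relatives. Compound 1 `C=C1CC[C@H]2[C@@](C)(CC[C@@H](OC(C)=O)[C@@]2(C)C(=O)OC)[C@@H]1CCC1=CCOC1=O` gives 80600 nM, and compound 3 `C=C1CC[C@H]2[C@@](C)(CC[C@@H](O)[C@@]2(C)C(=O)OCc2ccccc2)[C@@H]1CCC1=CCOC1=O` gives 37900 nM. Compound 4 `C=C1CC[C@H]2[C@@](C)(CC[C@@H](O)[C@@]2(C)C(=O)OC)[C@@H]1C/C=C1\C=COC1=O` has not been measured, and its change is a group of 7 heavy atoms (5 carbon, 2 oxygen; one five-membered non-aromatic ring with 1 hetero atom) in place of a group of 7 heavy atoms (5 carbon, 2 oxygen; one five-membered non-aromatic ring with 1 hetero atom), on a saturated chain carbon bound to a saturated ring carbon. The measured steps are small: hydrogen in place of acetyl gives a 1.3-fold lower number from compound 1 to compound 2 (0.12 log units; within the scatter), and phenyl in place of hydrogen gives a 1.6-fold lower number from compound 2 to compound 3 (0.20 log units; within the scatter). Neither step touches the group that changes here, so they are only a weak guide, and no step beyond the scatter is expected in this assay. The expected step is a 1.4-fold lower number from compound 2 to compound 4 (0.16 log units; within the scatter). For compound 4 the estimate is 42000 nM, with an expected range of 13000 nM to 95000 nM.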

Compound 4, half-maximal inhibitory concentration: 177000 nM
The estimate for compound 4 lay 4.2-fold (0.62 log units) below the measured number; measured number above the stated range.
By their numbers in this assay, from the lowest: compounds 3, 2 and 1 (each within the scatter of the next, the first and the last beyond it); then compound 4.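

Unlike the two earlier single changes, both within the scatter, this swap on a saturated chain carbon bound to a saturated ring carbon gives a weaker inhibitor in this assay (a 2.9-fold higher number from compound 2 to compound 4 (0.47 log units; beyond the scatter)). The two groups have the same count of heavy atoms, and the entering one has one more double bond outside aromatic rings, so even a change this small in composition can matter here. Nothing measured here gives the reason for this step. Still open, going by these compounds, is how a carboxylic acid or a longer chain at this place would read in this assay. Also open, on these data alone, is whether the same swap on compound 3 would give a similar step.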